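Extending the Chain from Compound 2 to Compound 3

A few compounds are considered here, and "the series" means these few. Any claim that something is new, unique, unknown or untested is made for them only; others in the source may bear on it.

Going by the values given here, compound 2 `CCCN(Cc1ccc(C(=O)NO)cc1)c1ncc(-c2ccc(C)cc2)s1` gives 5800 nM in a functional assay on HCT-116 cells (Homo sapiens) for antiproliferative activity, read by MTT assay, with a stated time of 48 h (a higher number here means a weaker inhibitor of growth, a lower number a stronger inhibitor of growth), the highest of the two numbers measured so far. Among the compounds with values here, compound 1 `Cc1ccc(OCCCCN(Cc2ccc(C(=O)NO)cc2)c2ncc(-c3ccc(C)cc3)s2)cc1` gives 580 nM in this assay, and the only step available is a 10-fold higher number from compound 1 to compound 2 (1.00 log units; beyond the scatter), which trimmed the same chain carbon down to a hydrogen. Compound 3 `CCCCCN(Cc1ccc(C(=O)NO)cc1)c1ncc(-c2ccc(C)cc2)s1` differs from compound 2 by ethyl in place of hydrogen on a saturated chain carbon, three bonds along the chain from a nitrogen on an aromatic ring, so that, read one bond further out, propyl becomes pentyl. This change rebuilds part of the chain length lost in the step from compound 1 to compound 2 but brings back none of the (4-methylphenoxy)methyl group, so a step in the direction of compound 1, smaller than the measured one, is expected. Compound 3 is estimated to give about 2500 nM in this assay, with a range from 1000 nM to 6000 nM. The expected step is a 2.3-fold lower number from compound 2 to compound 3 (0.37 log units; beyond the scatter).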

Compound 3, concentration for 50% growth inhibition: 23300 nM
Compound 3: middle estimate off by 9.3-fold (0.97 log units), on the low side, outside the stated range (above it).
By their numbers in this assay, from the lowest: compound 1; then compound 2; then compound 3.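

In this assay, the added ethyl on this saturated chain carbon moved the number away from compound 1, not towards it, with a 4.0-fold higher number from compound 2 to compound 3 (0.60 log units; beyond the scatter). Carbon chain length alone therefore does not account for the lower number of compound 1: the pentyl of compound 3 stands above the propyl of compound 2, and methyl in place of 4-methylphenoxy gives a 40-fold higher number from compound 1 to compound 3 (1.60 log units; beyond the scatter), so the advantage of compound 1 goes with the 4-methylphenoxy group. No measurement available here explains the rise seen with the pentyl chain.

Going by these compounds, it remains open whether that advantage needs the whole 4-methylphenoxy group, or whether a plain phenoxy, an amine or a carboxylic acid in its place would keep it. Also open, on these data alone, is how the number runs with butyl or hexyl in place of propyl.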